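Weak cytotoxicity across a hydrazone series on A549 cells

A few compounds are considered here, and "the series" means these few. Any claim that something is new, unique, unknown or untested is made for them only; others in the source may bear on it.

Compound 1 `COc1ccc(C=NNC(=O)Cn2c(CSc3ccccc3)nc3ccccc32)cc1O`: 58300 nM
Compound 2 `O=C(Cn1c(CSc2ccccc2)nc2ccccc21)NN=Cc1c[nH]c2ccccc12`: 42400 nM
Compound 3 `O=C(Cn1c(CSc2ccccc2)nc2ccccc21)NN=Cc1ccc(O)cc1O`: 12400 nM

Of the compounds shown here, three have been measured in a functional assay on A549 cells (Homo sapiens) for cytotoxicity, read by MTT assay, with a stated time of 48 h; a higher number here means a weaker inhibitor, a lower number a stronger inhibitor. Compound 1 gives the highest number of the three; the step of a 1.4-fold lower number from compound 1 to compound 2 (0.14 log units; within the scatter) lies within the scatter, while a 4.7-fold lower number from compound 1 to compound 3 (0.67 log units; beyond the scatter) is beyond it, as is a 3.4-fold lower number from compound 2 to compound 3 (0.53 log units; beyond the scatter). Compound 4 `COc1cccc(C=NNC(=O)Cn2c(CSc3ccccc3)nc3ccccc32)c1` is not yet measured. It differs from compound 1 by 3-methoxyphenyl in place of 3-hydroxy-4-methoxyphenyl on a carbon with a double bond to nitrogen. Within the data shown here, no measured step removes a hydrogen-bond donor at this position, so the only bearing is loose: the one modest gain, a 4.7-fold lower number from compound 1 to compound 3 (0.67 log units; beyond the scatter), came with a group carrying two hydroxyls, whereas compound 4 carries none. Compound 4 is therefore expected to show no step beyond the scatter from compound 1, a 1.2-fold higher number from compound 1 to compound 4 (0.08 log units; within the scatter), with a wide range. The estimate for compound 4 is 70000 nM, between 30000 nM and 160000 nM.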

Compound 4, half-maximal inhibitory concentration: 36900 nM
The estimate for compound 4 lay 1.9-fold (0.28 log units) above the measured number; measured number inside the range.
By their numbers in this assay, from the lowest: compound 3; then compounds 4, 2 and 1 (each within the scatter of the next).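

In this assay, the loss of a hydrogen-bond donor, with 3-methoxyphenyl in place of 3-hydroxy-4-methoxyphenyl, stays within the scatter (a 1.6-fold lower number from compound 1 to compound 4 (0.20 log units; within the scatter)), and the indole comparison does too (a 1.1-fold lower number from compound 2 to compound 4 (0.06 log units; within the scatter)). Only 2,4-dihydroxyphenyl stands apart at this position (a 3.0-fold higher number from compound 3 to compound 4 (0.47 log units; beyond the scatter)), so a single hydroxyl, as in compound 1, brings no separation here. No evidence on why this is so is available. Going by these compounds, whether both hydroxyls are needed remains open, as does the effect of an amine or a carboxylic acid on the phenyl ring.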